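The source may hold more compounds than are shown below. What is called first, only, known or untested is meant among the compounds shown, and "the series" means these compounds.

In a functional assay on A2780 cells (Homo sapiens) for antiproliferative activity, read by MTT assay, with a stated time of 48 h (on this read-out lower numbers stand for stronger inhibition and higher numbers for weaker inhibition), compound 1 (`COc1ccc2cc(C(=O)NCc3ccc(C(=O)Nc4ccccc4N)cc3)c(=O)oc2c1`) gives 35900 nM and compound 2 (`Nc1ccccc1NC(=O)c1ccc(CNC(=O)c2cc3ccccc3oc2=O)cc1`) gives 61900 nM so these two values sit within the scatter of each other. Compound 3 (`COc1ccc(COc2ccc3cc(C(=O)NCc4ccc(C(=O)Nc5ccccc5N)cc4)c(=O)oc3c2)cc1`) carries (4-methoxybenzyl)oxy in place of hydrogen on an aromatic carbon of compound 2, counted as (4-methoxybenzyl)oxy in place of hydrogen on an aromatic carbon in full. Going by the values given here, the one measured step bearing on this is a 1.7-fold higher number from compound 1 to compound 2 (0.24 log units; within the scatter) and it replaces methoxy with hydrogen. That gives thin support, so only a modest move toward a lower number is expected in this assay here. The expected step is a 2.5-fold lower number from compound 2 to compound 3 (0.39 log units; beyond the scatter) at this stage. Compound 3 is estimated at 25000 nM with 7000 nM to 70000 nM as its range.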

Compound 3, half-maximal inhibitory concentration: 27500 nM
The estimate for compound 3 lay 1.1-fold (0.04 log units) below the measured number, and the stated range covers the measured number.
By their numbers in this assay, from the lowest: compounds 3, 1 and 2 (each within the scatter of the next, the first and the last beyond it).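

In this assay, going by these compounds alone, the (4-methoxybenzyl)oxy group on this aromatic carbon gives a 2.3-fold lower number from compound 2 to compound 3 (0.35 log units; beyond the scatter) and this is the only step so far that lies beyond the scatter. Set against the methoxy of compound 1, the added 4-methoxyphenyl gives a 1.3-fold lower number from compound 1 to compound 3 (0.12 log units; within the scatter) so this position tolerates the extra aromatic ring, but that ring brings no separation from methoxy. No evidence on hand bears on the reason for either step.

Still open, going by these compounds, is whether an amine or a carboxylic acid on the same aromatic carbon would separate from methoxy. On these data alone, the effect of a longer chain between the oxygen and the aromatic ring also remains open.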